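Sulfone-bearing amide in place of the morpholine amide

The source may report more compounds than this note shows. Statements on the series, on what has been measured and on what is new or still open speak of the compounds shown alone.

Compound 1 `CC(C)[C@H](NC(=O)[C@H](CC(=O)O)NC(=O)CCCOc1ccc(C(=N)N)cc1)C(N)=O` and compound 2 `CC(C)[C@H](NC(=O)[C@H](CC(=O)O)NC(=O)CCCOc1ccc(C(=N)N)cc1)C(=O)N1CCOCC1` share one core and differ only at a carbonyl carbon. In a physicochemical assay for lipophilicity (on this read-out lower numbers stand for lower lipophilicity and higher numbers for higher lipophilicity), compound 1 gives 0.891 and compound 2 gives 0.716; the step is a number 0.18 log units lower from compound 1 to compound 2 (within the scatter), so the two numbers sit within the scatter of each other and compound 2 cannot be set apart from compound 1 on this read-out. Compound 3 `CC(C)[C@H](NC(=O)[C@H](CC(=O)O)NC(=O)CCCOc1ccc(C(=N)N)cc1)C(=O)N1CCS(=O)(=O)CC1` has not been measured; it carries the next change at the same carbonyl carbon: 1,1-dioxothiomorpholin-4-yl in place of morpholin-4-yl on a carbonyl carbon. Among the measured compounds shown here, no measured pair shows this exact exchange; the only step at that position is the small one from amino to morpholin-4-yl. Because a number 0.18 log units lower from compound 1 to compound 2 (within the scatter) pointed downward even for that smaller change, and the entering group counts two hydrogen-bond acceptors where one leaves, a downward step beyond the scatter is expected, about a number 0.42 log units lower from compound 2 to compound 3 (beyond the scatter). Compound 3 is therefore estimated at 0.3 in this assay, within a range from 0 to 0.65.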

Compound 3, partition coefficient: 0.804
Beside the measured number, compound 3's estimate is 0.50 log units below it; measured number outside the range, above it.
By their numbers in this assay, from the lowest: compounds 2, 3 and 1 (each within the scatter of the next).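

In this assay, 1,1-dioxothiomorpholin-4-yl in place of morpholin-4-yl on a carbonyl carbon gives a number 0.09 log units higher from compound 2 to compound 3 (within the scatter), so the higher hydrogen-bond acceptor count of the entering group comes with no step beyond the scatter. Set against the amino group, the same ring gives a number 0.09 log units lower from compound 1 to compound 3 (within the scatter), which means that all three groups at this carbonyl carbon now lie within the scatter of one another and this read-out does not separate them. No measurement on hand accounts for this result.

Still open, as far as these compounds go, is whether a group of another kind on this carbonyl carbon, such as a dimethylamino group or a piperazin-1-yl ring carrying a carboxylic acid, would move the number beyond the scatter. Also open, from the compounds shown here alone, is whether a step of that size can arise anywhere else on the shared core.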